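The source may report more compounds than this note shows. Statements on the series, on what has been measured and on what is new or still open speak of the compounds shown alone.

Among the measured compounds shown here, compound 3 `COc1cc(C2CC(c3cc4ccccc4o3)=NN2C(=O)Nc2ccc(Cl)cc2)ccc1O` is one of three compounds measured in a functional assay on microsomes from liver (Rattus norvegicus, strain Wistar) for inhibition, with a stated time of 15 min (on this read-out higher numbers stand for weaker inhibition and lower numbers for stronger inhibition), where compound 3 gives 121000000 nM. Compound 1 `COc1cc(C2CC(c3cc4ccccc4o3)=NN2C(=O)Nc2ccccc2)ccc1O` gives 116000000 nM in this assay, and compound 2 `COc1cc(C2CC(c3cc4ccccc4o3)=NN2C(=O)Nc2ccc(F)cc2)ccc1O` gives 125000000 nM. The three numbers lie within the scatter of one another, so compound 3 stands among them without any separation that the data would support. The steps that connect them are all small: a 1.0-fold higher number from compound 1 to compound 3 (0.02 log units; within the scatter), a 1.0-fold lower number from compound 2 to compound 3 (0.01 log units; within the scatter) and a 1.1-fold higher number from compound 1 to compound 2 (0.03 log units; within the scatter).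

Compound 4 `COc1cc(C2CC(c3cc4ccccc4o3)=NN2C(=O)Nc2ccc(O)c(O)c2)ccc1O` has not yet been measured. It differs from compound 3 by 3,4-dihydroxyphenyl in place of 4-chlorophenyl on an amide-type nitrogen. For the measured compounds named here, none of the measured steps touches a replacement of this kind; they only exchange hydrogen, fluoro and chloro on an aromatic carbon, and each of them left the number where it was. Nothing measured here supports a directional step for compound 4, so any expectation can rest only on the steady numbers of compounds 1 to 3 and on the fact that a wholly new kind of group enters. The step of a 1.0-fold lower number from compound 3 to compound 4 (0.00 log units; within the scatter) is therefore expected to stay within the scatter. Going by the values given here, compound 4 is estimated at 120000000 nM, with a range from 40000000 nM to 360000000 nM, the range kept wide since no measured step involves a hydroxy group.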

Compound 4, half-maximal inhibitory concentration: 11000000 nM
Compound 4: the middle estimate sits 11-fold (1.04 log units) above what was measured, and the stated range ends above it.
By their numbers in this assay, from the lowest: compound 4; then compounds 1, 3 and 2 (each within the scatter of the next).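

At the group on the amide-type nitrogen, phenyl, 4-fluorophenyl and 4-chlorophenyl gave numbers within the scatter of one another in this assay, yet 3,4-dihydroxyphenyl gives an 11-fold lower number from compound 3 to compound 4 (1.04 log units; beyond the scatter) and an 11-fold lower number from compound 2 to compound 4 (1.06 log units; beyond the scatter) and an 11-fold lower number from compound 1 to compound 4 (1.02 log units; beyond the scatter). This position is therefore not indifferent to what it carries: the lower number of compound 4 stands for stronger inhibition than that of any of the other three compounds, and the earlier exchanges of hydrogen, fluoro and chloro had given no sign of this. Nothing given here accounts for the size of this step, so the change can only be recorded as a measured difference.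

The compounds shown leave open whether a single hydroxy group on the phenyl would match the two of compound 4, and whether methoxy groups in their place would keep the lower number. They also leave open whether an amine or a carboxylic acid on the phenyl would move the number in the same way.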